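Shortening the alkenyl substituent in the pyridine-bearing series

The compounds below may be only part of what the source reports. "The series", "measured", "known", "first", "only" and "open" are said of these compounds alone.

Going by the values given here, compound 2 `CC(C(=O)NCc1ccc(C(F)(F)F)nc1C1=CCC(C(C)(C)C)CC1)c1ccc(NS(C)(=O)=O)c(F)c1` gives 0.2 nM in an assay on CHO cells for antagonist activity at transient receptor potential cation channel subfamily V member 1 (Homo sapiens), read by FLIPR and calcium flux (a lower number here means a stronger inhibitor, a higher number a weaker inhibitor), the lowest of the two numbers so far. Compound 1 `CC(C(=O)NCc1ccc(C(F)(F)F)nc1CCC(C)(C)C)c1ccc(NS(C)(=O)=O)c(F)c1` gives 0.6 nM in this assay, and the step of a 3.0-fold lower number from compound 1 to compound 2 (0.48 log units; beyond the scatter) is modest but beyond the scatter, so the larger cyclohexenyl group on the shared core is favoured over the open chain. Compound 3 `CC(C)=Cc1nc(C(F)(F)F)ccc1CNC(=O)C(C)c1ccc(NS(C)(=O)=O)c(F)c1` carries the change 2-methylprop-1-en-1-yl in place of 4-(tert-butyl)cyclohex-1-en-1-yl on an aromatic carbon: the ring-bearing group gives way to a shorter open-chain group with no ring. Among the compounds with values here, only the step of a 3.0-fold lower number from compound 1 to compound 2 (0.48 log units; beyond the scatter) bears on this, and it ran toward the larger group; the new group is smaller than either earlier one, so for compound 3 a loss beyond the scatter is expected. For compound 3 the estimated step is a 15-fold higher number from compound 2 to compound 3 (1.18 log units; beyond the scatter). Compound 3 is expected at 3 nM in this assay, with a range from 0.6 nM to 15 nM.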

Compound 3, inhibition constant: 11.5 nM
Compound 3: the middle estimate sits 3.8-fold (0.58 log units) below what was measured; the measured number falls inside the stated range.
By their numbers in this assay, from the lowest: compound 2; then compound 1; then compound 3.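

In this assay the position next to the ring nitrogen turns out to be much less forgiving of a small substituent than the first pair could show: 2-methylprop-1-en-1-yl in place of 4-(tert-butyl)cyclohex-1-en-1-yl gives a 58-fold higher number from compound 2 to compound 3 (1.76 log units; beyond the scatter) as a large step, well beyond the modest gap between the two larger groups. The ring alone does not account for the drop, since the open-chain 3,3-dimethylbutyl also holds a clear lead, with a 19-fold higher number from compound 1 to compound 3 (1.28 log units; beyond the scatter) as a large step to the shorter alkenyl group. No data are available here to explain the size of either loss.

Whether the number follows substituent size, the ring or the double bond stays open, since these features vary together across the compounds shown. A saturated isobutyl group or a small cyclopentenyl ring at this position would help separate them.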